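This account rests on a few compounds, and the source may have more. Where it says the series, first, only, none or still open, it means among the compounds named here.

Of the compounds shown here, three sharing one core have been measured. Compound 3 `COc1ccc(-c2cn(-c3cccc(C(=O)/C=C/c4cc(OC)c(OC)c(OC)c4)c3)c(=O)[nH]2)cc1` gives 2660 nM in a functional assay on NCI-H322M cells (Homo sapiens) for inhibition; on this read-out lower numbers stand for stronger inhibition of growth and higher numbers for weaker inhibition of growth. Compound 1 `COc1cc(/C=C/C(=O)c2cccc(-n3cc(-c4ccc(Cl)cc4)[nH]c3=O)c2)cc(OC)c1OC` gives 12900 nM, and compound 2 `COc1ccc(-c2cn(-c3cccc(C(=O)/C=C/c4ccc(O)c(OC)c4)c3)c(=O)[nH]2)cc1` gives 8200 nM; the values of compound 1 and compound 2 lie within the scatter of each other.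

The core of compound 2 differs from that of compound 3 by 4-hydroxy-3-methoxyphenyl in place of 3,4,5-trimethoxyphenyl on a double-bonded chain carbon bound to a double-bonded chain carbon, and on this read-out the step of a 3.1-fold lower number from compound 2 to compound 3 (0.49 log units; beyond the scatter). Within the core of compound 3, the change chloro in place of methoxy on an aromatic carbon produced the step of a 4.8-fold higher number from compound 3 to compound 1 (0.69 log units; beyond the scatter).

Compound 4 `COc1cc(/C=C/C(=O)c2cccc(-n3cc(-c4ccc(Cl)cc4)[nH]c3=O)c2)ccc1O` has not been measured. It differs from compound 2 by chloro in place of methoxy on an aromatic carbon. The place of this change is described in the same words as for the change from compound 3 to compound 1, so it is the same change made in the other core.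

From compound 2 to compound 4 the step is expected to be a 3.7-fold higher number from compound 2 to compound 4 (0.56 log units; beyond the scatter), because of the step of a 4.8-fold higher number from compound 3 to compound 1 (0.69 log units; beyond the scatter) seen for the same change in the other core, with the reservation that a single example carries no guarantee of transfer. For compound 4 the value is thus estimated at 30000 nM, likely falling between 12000 nM and 80000 nM.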

Compound 4, concentration for 50% growth inhibition: 4580 nM
Estimate against measurement, compound 4: 6.6-fold (0.82 log units) above, outside the stated range (below it).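

In this assay, going from 4-methoxyphenyl to 4-chlorophenyl on the core that carries the 4-hydroxy-3-methoxyphenyl group gives a 1.8-fold lower number from compound 2 to compound 4 (0.25 log units; within the scatter), so this pair cannot be told apart on this read-out. The change therefore did not carry over with its size intact, and the two cores do not respond alike: the same change on two cores in this assay, a 4.8-fold higher number (0.69 log units; beyond the scatter) from compound 3 to compound 1 and a 1.8-fold lower number (0.25 log units; within the scatter) from compound 2 to compound 4, 8.7-fold (0.94 log units) apart, beyond the scatter of two such steps This shows that, in this series, a step seen on one core cannot simply be transferred to the other, but with one pair per core it does not show why the two differ, nor whether the 3,4,5-trimethoxyphenyl or the 4-hydroxy-3-methoxyphenyl group would set the outcome in further pairs.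

The compounds shown leave open how a phenyl ring carrying fluoro, an amine or a carboxylic acid in place of chloro would read on each of the two cores. They also leave open whether the gap between the two cores would persist with a longer chain in place of the double-bonded chain.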